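A few compounds are considered here, and "the series" means these few. Any claim that something is new, unique, unknown or untested is made for them only; others in the source may bear on it.

Two compounds have a number in a functional assay on NB-4 cells (Homo sapiens) for inhibition, read by XTT assay, with a stated time of 48 h; on this read-out lower numbers stand for stronger inhibition and higher numbers for weaker inhibition. Compound 1, whose structure is `COc1ccc(C(=O)/C(=C/c2ccc([N+](=O)[O-])cc2)CC(C)C)cc1`, is the stronger of the two: in this assay compound 1 gives 600 nM. Compound 2, whose structure is `C=C(C(=O)c1ccc(OC)cc1)C(OC(C)=O)c1ccc(Cl)cc1Cl`, stands at the higher end: in this assay compound 2 gives 5400 nM. The gap between these two numbers is beyond the usual scatter of repeated measurements, so compound 2 is the weaker of the pair on this read-out; the two structures differ in several places at once, and the numbers alone say nothing about which of those differences matters.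

Compound 3, whose structure is `C=C(C(=O)c1ccc(OC)cc1)C(OC(C)=O)C1CCCCC1`, has not yet been measured. It carries a single change relative to compound 2: cyclohexyl in place of 2,4-dichlorophenyl on a saturated chain carbon bound to a double-bonded chain carbon and an oxygen next to a carbonyl group. Among the compounds with values here, no measured pair in this set shows what such a swap does, so the direction of any shift is open. The expectation is a step of a 1.1-fold higher number from compound 2 to compound 3 (0.05 log units; within the scatter) that stays within the scatter, with no clear move in either direction. On that basis compound 3 is expected to give about 6000 nM in this assay, with a plausible range from 2000 nM to 20000 nM.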

Compound 3, half-maximal inhibitory concentration: 10500 nM
Estimate against measurement, compound 3: 1.8-fold (0.24 log units) below; low and high end bracket the measured number.
By their numbers in this assay, from the lowest: compound 1; then compounds 2 and 3 (each within the scatter of the next).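

In this assay, cyclohexyl in place of 2,4-dichlorophenyl on a saturated chain carbon bound to a double-bonded chain carbon and an oxygen next to a carbonyl group gives a 1.9-fold higher number from compound 2 to compound 3 (0.29 log units; within the scatter) and so no shift that can be told apart from the usual variation between repeat measurements. Within the data shown here, at this position, then, a non-aromatic six-membered carbon ring without chlorine reads the same as the aromatic dichlorinated ring, which is the first direct information on this place in the molecule, since compound 1 differs from the other two in several places at once. The swap removes the aromatic ring and both chlorine atoms in one move, so this single pair cannot assign any part of the outcome to either feature, and nothing measured on these groups offers an explanation.

A plain phenyl ring would separate the role of the ring from that of the chlorine atoms. Going by these compounds, how an amine, a carboxylic acid or a short chain such as isopropyl would read at this position remains open, as does whether any group here can move the number beyond the scatter.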